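Estimating compound 3 from two measured neighbours

The source may report more compounds than this note shows. Statements on the series, on what has been measured and on what is new or still open speak of the compounds shown alone.

- compound 1 `CCNc1cc(-c2ccc(NC(=O)Nc3ccc(OC)cc3)cc2C)ccn1` gives 9950 nM
- compound 2 `CCNc1cc(-c2ccc(NC(=O)Nc3ccc(C(F)(F)F)cc3)cc2C)ccn1` gives 6870 nM

Both numbers come from a functional assay on MCF7 cells (Homo sapiens) for cytotoxicity, read by MTT assay, with a stated time of 24 h (on this read-out higher numbers stand for weaker inhibition and lower numbers for stronger inhibition), and they sit within the usual scatter of each other, so compound 2 cannot be ranked against compound 1 on these data. Repeating a measurement of this kind could produce a gap of this size on its own. Compound 3 `CCNc1cc(-c2ccc(NC(=O)Nc3c(C)cccc3C)cc2C)ccn1` has 2,6-dimethylphenyl in place of 4-(trifluoromethyl)phenyl on an amide-type nitrogen. Among the measured compounds shown here, no measured compound carries 2,6-dimethylphenyl, so the data offer no direct test of this change. For the measured compounds named here, the only guide is the single measured step (a 1.4-fold lower number from compound 1 to compound 2 (0.16 log units; within the scatter)), which put trifluoromethyl in place of methoxy on an aromatic carbon and stayed within the scatter. One small step is weak evidence, but it gives no reason to expect a large move in this assay and no clear direction. The expected step (a 1.2-fold higher number from compound 2 to compound 3 (0.09 log units; within the scatter)) is therefore no larger than the scatter. The estimated value for compound 3 is 8500 nM (expected range 3500 nM to 20000 nM).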

Compound 3, half-maximal inhibitory concentration: 7920 nM
The estimate for compound 3 lay 1.1-fold (0.03 log units) above the measured number; low and high end bracket the measured number.
By their numbers in this assay, from the lowest: compounds 2, 3 and 1 (each within the scatter of the next).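

At the amide-type nitrogen whose other neighbour is the carbonyl carbon, the read-out in this assay shows a 1.2-fold higher number from compound 2 to compound 3 (0.06 log units; within the scatter) for 2,6-dimethylphenyl in place of 4-(trifluoromethyl)phenyl, and a 1.3-fold lower number from compound 1 to compound 3 (0.10 log units; within the scatter) for the same group in place of 4-methoxyphenyl. The earlier pair differed only in one group carried on the phenyl ring, whereas compound 3 brings a phenyl ring with two methyl groups, and the three compounds still cannot be told apart in this assay, so these three substituted phenyl rings give no measurable preference at this place. Nothing measured on these compounds offers an explanation for this result.

As far as these compounds go, all three groups at this nitrogen are substituted phenyl rings, so it remains open what a non-aromatic group such as cyclohexyl, or a phenyl ring bearing an amine or a carboxylic acid, would give here. It is also open whether any group at this place can move the number beyond the scatter, since every step among these three compounds stays within it.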